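The source may hold more compounds than are shown below. What is called first, only, known or untested is meant among the compounds shown, and "the series" means these compounds.

Three analogues of one shared core have been run through a functional assay on MCF7 cells (Homo sapiens) for inhibition, read by sulforhodamine B assay; on this read-out lower numbers stand for stronger inhibition and higher numbers for weaker inhibition. Compound 1 `O=C1C(Nc2cccc(Cl)c2)=CC(=O)c2c1nc1n2[C@H]2OC[C@@H](O)[C@H]2OC1` gives 2970 nM in this assay. Compound 2 `COc1cccc(NC2=CC(=O)c3nc4n(c3C2=O)[C@H]2OC[C@@H](O)[C@H]2OC4)c1` returns only a limit of the assay in this assay, > 4000 nM. Compound 3 `CCOc1ccccc1NC1=CC(=O)c2nc3n(c2C1=O)[C@H]1OC[C@@H](O)[C@H]1OC3` likewise returns a limit in this assay, > 4000 nM. Among the measured compounds shown here, the single measured step between neighbours, a step that the two limits leave unreadable from compound 2 to compound 3, is left unreadable by the two limits. Where compound 2 stands is therefore fixed by the limit of > 4000 nM in this assay, at which 2 of the 3 values shown sit, rather than by a number. Compound 1 alone carries a read value.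

Compound 4 `O=C1C=C(N2CCCCC2)C(=O)c2c1nc1n2[C@H]2OC[C@@H](O)[C@H]2OC1` is the next one to be tested. It differs from compound 2 in one place: piperidin-1-yl in place of (3-methoxyphenyl)amino on a double-bonded ring carbon

No measured step bears directly on this exchange; the only one shown swaps one aryl group for another on the amine nitrogen and has no readable size. With compound 2 itself sitting at a limit, no direction can be drawn from the numbers shown, so the step that the limit leaves unreadable from compound 2 to compound 4 is expected to stay within the region of limits rather than amount to a change beyond the scatter. Compound 4 is accordingly estimated at 5000 nM, with a range from 2000 nM to 20000 nM.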

Compound 4, half-maximal inhibitory concentration: > 8000 nM
Compound 4: no number, only a limit; the forecaster's own chance of this, stated with the estimate: 60%; at least 1.6-fold (0.20 log units) between middle value and limit.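

Among the compounds shown here, compound 2 and compound 4 both return only limits in this assay, so no step between them can be read. The compounds shown leave open whether piperidin-1-yl or (3-methoxyphenyl)amino on the double-bonded ring carbon goes with stronger inhibition, and how large any such difference would be.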